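A few compounds are considered here, and "the series" means these few. Any claim that something is new, unique, unknown or untested is made for them only; others in the source may bear on it.

In an assay on CHO-K1 cells for displacement of a labelled ligand from adenosine receptor A1 (Homo sapiens), read by scintillation counting, with a stated time of 60 min (a higher number here means a weaker inhibitor, a lower number a stronger inhibitor), the three measured compounds stand as follows:

compound 1 `CCCCC/C=C/C=C/C=N/Nc1nc(N)c2ncn([C@@H]3O[C@H](CO)[C@@H](O)[C@H]3O)c2n1`: 2 nM
compound 2 `CC(=O)Nc1ccc(/C=N/Nc2nc(N)c3ncn([C@@H]4O[C@H](CO)[C@@H](O)[C@H]4O)c3n2)cc1`: > 10000 nM
compound 3 `CCCOc1ccc(/C=N/Nc2nc(N)c3ncn([C@@H]4O[C@H](CO)[C@@H](O)[C@H]4O)c3n2)cc1`: > 10000 nM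

Compound 2 gives only a limit of the assay in this assay, not a number. Compound 3 likewise gives only a limit. Compound 1 is the only one of the three with a measured number. The step of an at least 5000-fold higher number from compound 1 to compound 2 (3.69 log units; beyond the scatter) is large, and the step of an at least 5000-fold higher number from compound 1 to compound 3 (3.69 log units; beyond the scatter) is large as well. The step that the two limits leave unreadable from compound 2 to compound 3 cannot be read, because of the limit of > 10000 nM in this assay, at which 2 of the 3 values shown sit.

Compound 4 `CN(C)c1ccc(/C=N/Nc2nc(N)c3ncn([C@@H]4O[C@H](CO)[C@@H](O)[C@H]4O)c3n2)cc1` differs from compound 2 by dimethylamino in place of acetamido on an aromatic carbon. Going by the values given here, the one measured step of a comparable kind, propoxy in place of acetamido, has no readable size, so no measured step in this assay tells how a change on that aromatic carbon moves the number. The estimate for compound 4 therefore rests on where compound 2 stands, at the limit. Compound 4 is expected to remain weak in this assay, with an estimated value of 10000 nM, between 2000 nM and 50000 nM. The step of a number no higher from compound 2 to compound 4 (the limit leaves the size open) is thus expected to be none beyond the scatter, and a further limit rather than a number is the likelier outcome.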

Compound 4, inhibition constant: > 10000 nM
Compound 4: no number, only a limit; the forecaster's own chance of this, stated with the estimate: 70%; the middle value sits exactly at the limit.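

In this assay compound 4 gives > 10000 nM, which is a limit and not a number. With dimethylamino, which has no hydrogen-bond donors where acetamido has one, a third group on this aromatic carbon, para to a large group, now stays at that limit, and the exchange of the whole group on the carbon with a double bond to nitrogen gives an at least 5000-fold higher number from compound 1 to compound 4 (3.69 log units; beyond the scatter), so the large step seen earlier also holds for the 4-(dimethylamino)phenyl group. The steps from compound 2 to compound 4 and from compound 3 to compound 4 cannot be read, because of this: the limit of > 10000 nM in this assay, at which 3 of the 4 values shown sit.

The compounds shown therefore leave open whether any group on this aromatic carbon changes the value at all, and whether the large steps go with the aromatic ring itself or with the groups it carries. An unsubstituted phenyl, a carboxylic acid on the ring, or an open chain shorter or longer than that of compound 1 could begin to separate these possibilities.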